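The compounds below may be only part of what the source reports. "The series", "measured", "known", "first", "only" and "open" are said of these compounds alone.

In a functional assay on MCF7 cells (Homo sapiens) for antiproliferative activity, read by MTT assay, with stated times of 24 h and 72 h (on this read-out higher numbers stand for weaker inhibition and lower numbers for stronger inhibition), the measured compounds give these values:
Compound 1 `COc1ccc([C@@H]2[C@H](Oc3ccccc3)C(=O)N2c2cc(OC)c(OC)c(OC)c2)cc1` gives 35000 nM
Compound 2 `COc1cc(N2C(=O)[C@@H](Oc3ccccc3)[C@H]2c2ccc(S(C)(=O)=O)cc2)cc(OC)c1OC` gives 62000 nM
Compound 3 `COc1cc(N2C(=O)[C@@H](Oc3ccccc3)[C@H]2c2ccc(N)cc2)cc(OC)c1OC` gives 160000 nM

Compound 1 sits at the low end of these numbers. The result a 1.8-fold higher number from compound 1 to compound 2 (0.25 log units; within the scatter) stays within the scatter, while a 4.6-fold higher number from compound 1 to compound 3 (0.66 log units; beyond the scatter) goes beyond it. Compound 4 `COc1ccc([C@@H]2[C@H](Oc3ccccc3)C(=O)N2c2cc(OC)c(OC)c(OC)c2)cc1NC(=O)CN` keeps the core of compound 1 and differs by ((aminomethyl)carbonyl)amino in place of hydrogen on an aromatic carbon in a change that places ((aminomethyl)carbonyl)amino in place of hydrogen on an aromatic carbon. Going by the values given here, no measured step makes this change, since both steps from compound 1 replace a methoxy group, so they are only loose guides. A modest step to a higher number, meaning weaker inhibition, is therefore expected in this assay with low confidence. The expected change is a 2.0-fold higher number from compound 1 to compound 4 (0.30 log units; within the scatter) on this estimate. Compound 4 is estimated at 70000 nM with an expected range from 20000 nM to 250000 nM overall.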

Compound 4, half-maximal inhibitory concentration: 6500 nM
Beside the measured number, compound 4's estimate is 11-fold (1.03 log units) above it; the whole stated range lies above it.
By their numbers in this assay, from the lowest: compound 4; then compounds 1 and 2 (each within the scatter of the next); then compound 3.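

In this assay, going by these compounds alone, adding ((aminomethyl)carbonyl)amino on an aromatic carbon ortho to a methoxy group gives a 5.4-fold lower number from compound 1 to compound 4 (0.73 log units; beyond the scatter), the first step here toward stronger inhibition. The earlier steps shown here replaced a methoxy group and none gave a lower number, whereas this one keeps every group of compound 1 and replaces only a hydrogen. Nothing available explains this gain. The compounds shown leave open whether the terminal amine is needed, which an acetylamino group at this position would test. On these data alone, whether a plain amine or a longer aminoalkyl amide chain would serve there also stays open.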